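This account rests on a few compounds, and the source may have more. Where it says the series, first, only, none or still open, it means among the compounds named here.

Compound 1 `CC1=C(C(=O)Nc2cccc([N+](=O)[O-])c2)C(c2ccc(O)cc2O)NC(NN2C(=O)/C(=C\c3ccco3)SC2=S)=N1`: > 100000 nM, a limit of the assay
Compound 2 `CC1=C(C(=O)Nc2cccc([N+](=O)[O-])c2)C(c2ccc(O)cc2O)NC(NN2C(=O)/C(=C\c3cccs3)SC2=S)=N1`: 4500 nM

Among the measured compounds shown here, in a functional assay on HCT-116 cells (Homo sapiens) for inhibition, read by sulforhodamine B assay, with a stated time of 2 days (a lower number here means a stronger inhibitor of growth, a higher number a weaker inhibitor of growth), compound 2 gives 4500 nM, the only actual number so far. The other reading, for compound 1, is a limit and not a number. Compound 3 `CC1=C(C(=O)Nc2cccc([N+](=O)[O-])c2)C(c2ccc(O)cc2O)NC(NN2C(=O)/C(=C\c3ccccc3)SC2=S)=N1` has phenyl in place of thiophen-2-yl on a double-bonded chain carbon bound to a double-bonded ring carbon. For the measured compounds named here, one measured step bears on this place: thiophen-2-yl replacing furan-2-yl gave an at least 22-fold lower number from compound 1 to compound 2 (1.34 log units; beyond the scatter), a large step. It shows that changes here can matter greatly in this assay, but this single step does not settle the direction for phenyl. A modest step towards a higher number is therefore expected, with wide uncertainty. The estimated change is a 1.8-fold higher number from compound 2 to compound 3 (0.25 log units; within the scatter). For compound 3 the expected value is 8000 nM, with an estimated range of 2000 nM to 40000 nM.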

Compound 3, concentration for 50% growth inhibition: 16600 nM
Estimate against measurement, compound 3: 2.1-fold (0.32 log units) below; low and high end bracket the measured number.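

With phenyl at this place, growth inhibition in this assay is retained but is weaker than with thiophen-2-yl (a 3.7-fold higher number from compound 2 to compound 3 (0.57 log units; beyond the scatter)). Phenyl also separates from furan-2-yl (an at least 6.0-fold lower number from compound 1 to compound 3 (0.77 log units; beyond the scatter)), so the three rings now fall in the order thiophen-2-yl, phenyl, furan-2-yl, and the large gap between the two five-membered rings is not a simple divide between five- and six-membered rings. The end of this order at compound 1 is a limit and not a number: the limit of > 100000 nM in this assay, at which 1 of the 3 values shown sits.

The compounds shown leave open whether a saturated ring such as cyclohexyl, or a phenyl carrying a methoxy group or a chlorine atom, would match or pass compound 2 at this place. They also leave open whether this order of rings holds when other groups on the shared core are changed.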